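The source may report more compounds than this note shows. Statements on the series, on what has been measured and on what is new or still open speak of the compounds shown alone.

Of the compounds shown here, two have been measured in a functional assay on HEK293 cells for antagonist activity at Voltage-dependent L-type calcium channel subunit alpha-1D (Rattus norvegicus), read by FLIPR; a higher number here means a weaker inhibitor, a lower number a stronger inhibitor. Compound 1, `CCOC(=O)C1=C(C)NC(COC)=C(C(=O)OC)C1c1ccccc1[N+](=O)[O-]`, gives 790 nM in this assay. Compound 2, `COC(=O)C1=C(C)NC(C)=C(C(=O)OCCCl)C1c1cccc([N+](=O)[O-])c1`, gives 22 nM in this assay, the lowest of the two numbers; its nearest neighbour is compound 1, whose number is higher by a margin that lies well beyond the scatter of repeated measurements. Among the compounds with values here, compounds 1 and 2 differ in several places at once, so no single step between them can be read from their values; only the two numbers themselves stand.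

Compound 3, `COC(=O)C1=C(C)NC(C)=C(C(=O)OCCCOc2ccccc2)C1c1cccc([N+](=O)[O-])c1`, has not yet been measured. It differs from compound 2 in one place: phenoxymethyl in place of chloro on a saturated chain carbon, two bonds along the chain from an oxygen next to a carbonyl group. Because compound 2 already gives 22 nM, the starting point for compound 3 is a strong one. Within the data shown here, with no measured step of the same kind available, a step of modest size is expected, in the direction of a slightly lower number or none beyond the scatter, which as a step reads a 1.5-fold lower number from compound 2 to compound 3 (0.17 log units; within the scatter). For compound 3 in this assay a value of about 15 nM is estimated, within a range from 4 nM to 60 nM.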

Compound 3, half-maximal inhibitory concentration: 11 nM
Compound 3: middle estimate off by 1.4-fold (0.13 log units), on the high side; the range from low to high includes it.
By their numbers in this assay, from the lowest: compounds 3 and 2 (each within the scatter of the next); then compound 1.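

Within the data shown here, compound 2 and compound 3 give the first single-place comparison, and it concerns a saturated chain carbon, two bonds along the chain from an oxygen next to a carbonyl group. In this assay, replacing chloro, with 1 heavy atom and no ring, by phenoxymethyl, with 8 heavy atoms, one six-membered aromatic ring of carbon only and 1 hydrogen-bond acceptor, reads as a 2.0-fold lower number from compound 2 to compound 3 (0.30 log units; within the scatter), so this substantial difference in the group at this place leaves the two values within the scatter of each other. Nothing available explains why the two values stand together, and how the compounds behave beyond these numbers remains unaddressed. Compound 1 differs from the other two in several places, so its steps to them cannot be read, and what its other differences contribute stays unresolved. Whether this place would keep such values with an amine, a carboxylic acid or a longer chain on the same carbon remains open, as the two groups shown here, chloro and phenoxymethyl, support no wider pattern.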